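Working notes: variations on the ring amine nitrogen of one core

The source may report more compounds than this note shows. Statements on the series, on what has been measured and on what is new or still open speak of the compounds shown alone.

Of the compounds shown here, three of one shared core have been measured in a functional assay on HL-60 cells (Homo sapiens) for antiproliferative activity, with a stated time of 24 h; on this read-out lower numbers stand for stronger inhibition and higher numbers for weaker inhibition. Compound 1 `N#Cc1ccccc1CN1CCc2c(sc(NC(=O)c3ccccc3Cl)c2C(N)=O)C1` gives 10400 nM in this assay. Compound 2 `NC(=O)c1c(NC(=O)c2ccccc2Cl)sc2c1CCN(C(=S)Nc1cccc3ccccc13)C2` gives 13400 nM in this assay. Compound 3 `NC(=O)c1c(NC(=O)c2ccccc2Cl)sc2c1CCN(C(=O)Nc1ccccc1Cl)C2` gives 12500 nM in this assay. Compound 3 thus stands second highest of the three numbers; its nearest neighbour is compound 2, whose value lies within the scatter of that of compound 3, and the furthest is compound 1, also within the scatter. Within the data shown here, the one pair of measured compounds that differ in a single place gives a 1.2-fold higher number from compound 1 to compound 3 (0.08 log units; within the scatter), a change that did not move the number beyond the scatter.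

Compound 4 `NC(=O)c1c(NC(=O)c2ccccc2Cl)sc2c1CCN(C(=S)Nc1c(Cl)cccc1Cl)C2` has not yet been measured. Among the measured compounds shown here, it differs from compound 3 in one place: a group of 11 heavy atoms (7 carbon, 1 nitrogen, 1 sulfur, 2 chlorine; one six-membered aromatic ring of carbon only) in place of a group of 10 heavy atoms (7 carbon, 1 nitrogen, 1 oxygen, 1 chlorine; one six-membered aromatic ring of carbon only), on an amine nitrogen in a ring The only measured step bearing on this change, a 1.2-fold higher number from compound 1 to compound 3 (0.08 log units; within the scatter), lies within the scatter, and the values of compound 2 and compound 3, which also differ only on an amine nitrogen in a ring, sit within the scatter of each other. No step beyond the scatter is therefore expected in this assay from compound 3 to compound 4, no change at the digits printed from compound 3 to compound 4 (within the scatter). Compound 4 is estimated at 12500 nM, with an expected range from 6000 nM to 26000 nM.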

Compound 4, half-maximal inhibitory concentration: 3950 nM
For compound 4 the middle estimate is 3.2-fold (0.50 log units) above the measured one; measured number below the stated range.
By their numbers in this assay, from the lowest: compound 4; then compounds 1, 3 and 2 (each within the scatter of the next).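

Substitution on an amine nitrogen in a ring of the shared core can move the number in this assay beyond the scatter, which none of the earlier compounds showed: compound 4 stands apart with a 3.2-fold lower number from compound 3 to compound 4 (0.50 log units; beyond the scatter), together with a 3.4-fold lower number from compound 2 to compound 4 (0.53 log units; beyond the scatter) and a 2.6-fold lower number from compound 1 to compound 4 (0.42 log units; beyond the scatter), and so has the lowest number of the four. Sulfur in the group on this nitrogen does not by itself give the lower number, since compound 2 also carries it and differs from compound 4 in having naphthalen-1-yl where compound 4 has 2,6-dichlorophenyl on an amide-type nitrogen. Nothing available gives a reason for the lower number of compound 4.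

As far as these compounds go, the step from compound 3 exchanges oxygen for sulfur and adds a second chlorine at once, so the share of each remains open; (2,6-dichlorophenyl)carbamoyl on the same nitrogen would separate the two. Whether chlorine itself matters also stays unsettled, and a phenyl ring with methyl in place of both chlorines, on the same sulfur-bearing group, would address that.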